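The source may report more compounds than this note shows. Statements on the series, on what has been measured and on what is new or still open speak of the compounds shown alone.

In a functional assay on HPAC cells (Homo sapiens) for inhibition, read by MTT assay, with a stated time of 72 h (on this read-out lower numbers stand for stronger inhibition of growth and higher numbers for weaker inhibition of growth), compound 1 `O=S(=O)(NCCCNCc1ccc(Cl)c(Cl)c1)c1cc(C(F)(F)F)cc(C(F)(F)F)c1` gives 2500 nM. Compound 2 `COc1ccc(CNCCCNS(=O)(=O)c2cc(C(F)(F)F)cc(C(F)(F)F)c2)cc1OC` gives 3500 nM in this assay. Compound 3 `O=S(=O)(NCCCNCc1ccc(Br)cc1)c1cc(C(F)(F)F)cc(C(F)(F)F)c1` gives 2900 nM in this assay, a number that lies between those of compound 1 and compound 2 and is within the scatter of both, so the three cannot be told apart.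

Compound 4 `COc1cccc(CNCCCNS(=O)(=O)c2cc(C(F)(F)F)cc(C(F)(F)F)c2)c1` differs from compound 3 by 3-methoxyphenyl in place of 4-bromophenyl on a saturated chain carbon bound to an amine nitrogen. The steps already measured at this place all stay within the scatter: a 1.2-fold higher number from compound 1 to compound 3 (0.06 log units; within the scatter), a 1.2-fold lower number from compound 2 to compound 3 (0.08 log units; within the scatter) and a 1.4-fold higher number from compound 1 to compound 2 (0.15 log units; within the scatter). Exchanging one substituted phenyl group for another on the saturated chain carbon bound to the amine nitrogen has so far left this assay unchanged, and compound 2 already carries methoxy groups without any step beyond the scatter. No step beyond the scatter is therefore expected for the change to compound 4, in either direction, and the expected step is a 1.0-fold higher number from compound 3 to compound 4 (0.01 log units; within the scatter). Compound 4 is estimated to give 3000 nM in this assay, with a range from 1500 nM to 6000 nM.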

Compound 4, concentration for 50% growth inhibition: 2400 nM
Compound 4: the middle estimate sits 1.3-fold (0.10 log units) above what was measured; the range from low to high includes it.
By their numbers in this assay, from the lowest: compounds 4, 1, 3 and 2 (each within the scatter of the next).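

The 3-methoxyphenyl group leaves this assay within the scatter of every earlier compound, with a 1.2-fold lower number from compound 3 to compound 4 (0.08 log units; within the scatter), a 1.0-fold lower number from compound 1 to compound 4 (0.02 log units; within the scatter) and a 1.5-fold lower number from compound 2 to compound 4 (0.16 log units; within the scatter). The last of these steps adds something new: hydrogen in place of methoxy on an aromatic carbon, a smaller change than exchanging the whole aryl group, also stays within the scatter, so the four compounds still cannot be told apart at this position. Nothing shown gives a reason for this lack of separation.

The compounds shown leave open whether a carboxylic acid or an amine on the phenyl group in place of methoxy would produce a step beyond the scatter. They also leave open whether a longer chain on the amine nitrogen would do so.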